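The source may report more compounds than this note shows. Statements on the series, on what has been measured and on what is new or still open speak of the compounds shown alone.

Values in a functional assay on MCF7 cells (Homo sapiens) for cytotoxicity, read by MTT assay, with a stated time of 3 days; on this read-out lower numbers stand for stronger inhibition and higher numbers for weaker inhibition:
Compound 1 `COc1cccc(-c2cccc(O)c2)c1`: 33 ug/mL
Compound 2 `COc1ccc(-c2cccc(O)c2)cc1`: 48 ug/mL
Compound 3 `COc1ccc(-c2ccccc2)cc1OC`: 45 ug/mL

These three numbers lie within the usual scatter of one another, so the series shows no separation so far. Compound 3, at 45 ug/mL, stands closest to compound 2 and is also within the scatter of compound 1. None of the three can be called stronger or weaker than the others.

The next compound is compound 4 `COc1ccc(-c2cccc(O)c2)cc1OC`. It has hydroxy in place of hydrogen on an aromatic carbon of compound 3, on a six-membered aromatic ring of carbon only, meta to a large group (hydroxy in place of hydrogen on an aromatic carbon). Among the measured compounds shown here, no two measured compounds differ in one place only, so the data hold no direct measure of this change. For the measured compounds named here, the only guide is indirect: compound 1 and compound 2 both carry a hydroxy, and compound 2, at 48 ug/mL, is within the scatter of compound 3. A step of any clear size in either direction is therefore not expected. The estimated step of a 1.2-fold lower number from compound 3 to compound 4 (0.07 log units; within the scatter) is expected to stay within the scatter. For compound 4 the estimated value is 38 ug/mL, with an expected range from 18 ug/mL to 75 ug/mL.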

Compound 4, half-maximal inhibitory concentration: 48 ug/mL
Compound 4: the middle estimate sits 1.3-fold (0.10 log units) below what was measured; low and high end bracket the measured number.
By their numbers in this assay, from the lowest: compounds 1, 3, 2 and 4 (each within the scatter of the next).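

In this assay, placing a hydroxy on an aromatic carbon, meta to a large group, gives a 1.1-fold higher number from compound 3 to compound 4 (0.03 log units; within the scatter) and so provides the first direct measure of this change, which leaves the compounds unseparated. The gain of a methoxy can now be read from two starting points, as no change at the digits printed from compound 2 to compound 4 (within the scatter) and as a 1.5-fold higher number from compound 1 to compound 4 (0.16 log units; within the scatter), and neither step separates the compounds it joins, so neither the added hydroxy nor the added methoxy shifts the read-out by more than repeated measurements would. No other measurement bears on these results, and they stand without explanation.

On these data alone, the four compounds carry only hydroxy and methoxy groups on the shared core, so it remains open whether an amine, a carboxylic acid or a longer chain at this position would give a step beyond the scatter. As far as these compounds go, it also remains open whether any change to this core can separate two compounds in this assay, since every step read so far lies within the scatter.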